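From Methyl to Dimethylamino on a Saturated Ring

A few compounds are considered here, and "the series" means these few. Any claim that something is new, unique, unknown or untested is made for them only; others in the source may bear on it.

In a functional assay on HepG2 cells (Homo sapiens) for antiproliferative activity, read by MTT assay, with a stated time of 72 h (on this read-out lower numbers stand for stronger inhibition and higher numbers for weaker inhibition), compound 2 `COc1cc2c(Nc3ccc(C#N)cc3)ncnc2cc1OCCCN1CCC(C)CC1` gives 32100 nM and stands level within the scatter with compound 1 `COc1cc2c(Nc3ccc(C#N)cc3)ncnc2cc1OCCCN1CCCCC1` at 20700 nM while compound 3 `COc1cc2c(Nc3ccc(C#N)cc3)ncnc2cc1OCCCN1CCC(c2ccccc2)CC1` at 4610 nM lies clearly lower. Going by the values given here, compound 4 `COc1cc2c(Nc3ccc(C#N)cc3)ncnc2cc1OCCCN1CCC(N(C)C)CC1` has not yet been measured and differs from compound 2 by dimethylamino in place of methyl on a saturated ring carbon as its only change. Among the compounds with values here, two measured steps bear on this: a 1.6-fold higher number from compound 1 to compound 2 (0.19 log units; within the scatter) for methyl in place of hydrogen, and a 7.0-fold lower number from compound 2 to compound 3 (0.84 log units; beyond the scatter) for phenyl in place of methyl. Dimethylamino, like methyl and unlike phenyl, has no ring, so the first step is the closer guide, and this assay is expected to show no step beyond the scatter. The expected step is a 1.5-fold lower number from compound 2 to compound 4 (0.16 log units; within the scatter) and stays within the scatter. Compound 4 is expected at 22000 nM with an estimated range from 8000 nM to 50000 nM in this measurement.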

Compound 4, half-maximal inhibitory concentration: 33600 nM
The estimate for compound 4 lay 1.5-fold (0.18 log units) below the measured number; the range from low to high includes it.
By their numbers in this assay, from the lowest: compound 3; then compounds 1, 2 and 4 (each within the scatter of the next).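

In this assay dimethylamino on the saturated ring carbon gives a 1.0-fold higher number from compound 2 to compound 4 (0.02 log units; within the scatter) and a 1.6-fold higher number from compound 1 to compound 4 (0.21 log units; within the scatter) so a larger group carrying a nitrogen reads level with both methyl and hydrogen here. Among the groups shown at this place, only phenyl stands apart, with a 7.3-fold higher number from compound 3 to compound 4 (0.86 log units; beyond the scatter) and the level reading of the other three now spans a group with a hydrogen-bond acceptor. Nothing shown accounts for this result. As far as these compounds go, whether a benzyl or pyridyl group would keep the lower number seen with phenyl stays open, as does whether a primary amine or a carboxylic acid would read level with dimethylamino.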